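The source may hold more compounds than are shown below. What is called first, only, known or untested is meant among the compounds shown, and "the series" means these compounds.

Of the compounds shown here, three that share one core have been measured in an assay on CHO-K1 cells for displacement of a labelled ligand from adenosine receptor A1 (Homo sapiens), read by scintillation counting, with a stated time of 60 min; a higher number here means a weaker inhibitor, a lower number a stronger inhibitor. Compound 1 `CC(/C=N/Nc1nc(N)c2ncn([C@@H]3O[C@H](CO)[C@@H](O)[C@H]3O)c2n1)Cc1ccc(C(C)C)cc1` gives 9500 nM in this assay. Compound 2 `N#Cc1ccc(/C=N/Nc2nc(N)c3ncn([C@@H]4O[C@H](CO)[C@@H](O)[C@H]4O)c3n2)cc1` gives 4.1 nM, and compound 3 `Nc1nc(N/N=C/c2cccc(OCc3ccccc3)c2)nc2c1ncn2[C@@H]1O[C@H](CO)[C@@H](O)[C@H]1O` gives 13 nM. Compound 2 thus has the lowest number of the three; compound 3 stands nearest to it, compound 1 furthest, and both gaps lie beyond the usual scatter. Compound 4 `CCCCc1nc(/C=N/Nc2nc(N)c3ncn([C@@H]4O[C@H](CO)[C@@H](O)[C@H]4O)c3n2)c(Cl)[nH]1` has not yet been measured. It differs from compound 2 in one place: 2-butyl-5-chloro-1H-imidazol-4-yl in place of 4-cyanophenyl on a carbon with a double bond to nitrogen. An aromatic ring remains on the carbon with a double bond to nitrogen, as in compound 2 and compound 3, whereas compound 1, which carries no such ring, gives the highest number. Since the move to a five-membered aromatic ring with 2 hetero atoms and a chlorine goes beyond anything measured here, a moderate rise in number, beyond the scatter, is expected. Compound 4 is expected to give 30 nM in this assay, with a range from 5 nM to 300 nM. The expected step is a 7.3-fold higher number from compound 2 to compound 4 (0.86 log units; beyond the scatter).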

Compound 4, inhibition constant: 12 nM
For compound 4 the middle estimate is 2.5-fold (0.40 log units) above the measured one, and the stated range covers the measured number.
By their numbers in this assay, from the lowest: compound 2; then compounds 4 and 3 (each within the scatter of the next); then compound 1.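

Going from the six-membered aromatic ring of carbon only to a five-membered aromatic ring with 2 hetero atoms, this assay shows a 2.9-fold higher number from compound 2 to compound 4 (0.47 log units; beyond the scatter). So 4-cyanophenyl is not essential on the carbon with a double bond to nitrogen: the much-changed 2-butyl-5-chloro-1H-imidazol-4-yl group, which adds a hydrogen-bond donor and has more heavy atoms, costs only a modest step. Nothing shown here explains why the number moves in this direction.

The ring, the butyl chain and the chlorine all enter together in this single change, and the compounds shown do not separate their individual contributions. Still open, from the compounds shown here alone, is how the number would respond to a methyl group in place of the butyl chain, or to a bromine or a hydrogen in place of the chlorine.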